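Swapping an amide for an ester on a CDK8 scaffold

The source may report more compounds than this note shows. Statements on the series, on what has been measured and on what is new or still open speak of the compounds shown alone.

Measured so far:
compound 1, `CNC(=O)/C=C/c1ccncc1-c1ccc2ccccc2c1`, 12.4 nM
compound 2, `O=C(/C=C/c1ccncc1-c1ccc2[nH]ccc2c1)N1CCOCC1`, 190 nM

Both values come from an assay on a protein complex for inhibition of CDK8/Cyclin C (Homo sapiens), with a stated time of 1 h; on this read-out lower numbers stand for stronger inhibition and higher numbers for weaker inhibition. Of the two numbers, compound 2 gives the higher one, 190 nM, while compound 1 gives a much lower one, 12.4 nM; that gap lies well beyond the scatter of the assay. The two compounds differ in more than one place, so nothing can be attributed to any single part of them.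

Compound 3, `CCOC(=O)/C=C/c1ccncc1-c1ccc2[nH]ccc2c1`, has not yet been measured. It keeps everything in compound 2 except one group: ethoxy in place of morpholin-4-yl on a carbonyl carbon. The carbonyl and the chain on which it sits stay in place; only what hangs on the other side of the carbonyl changes.

Going by the values given here, no measured pair shows what this particular swap does, so any expectation is uncertain. The expected result is that compound 3 stays near compound 2, perhaps a little weaker, with a step of a 1.7-fold higher number from compound 2 to compound 3 (0.23 log units; within the scatter) in this assay. On that basis the estimate for compound 3 is 320 nM, within a range from 80 nM to 1500 nM.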

Compound 3, half-maximal inhibitory concentration: 107 nM
Compound 3: middle estimate off by 3.0-fold (0.48 log units), on the high side; the range from low to high includes it.
By their numbers in this assay, from the lowest: compound 1; then compounds 3 and 2 (each within the scatter of the next).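

In this assay, going by these compounds alone, ethoxy in place of morpholin-4-yl on a carbonyl carbon gives a 1.8-fold lower number from compound 2 to compound 3 (0.25 log units; within the scatter), the first comparison here of compounds that differ in one place only. The assay therefore cannot tell these two groups apart on this core: the six-membered ring can go, and the group can shrink from 6 heavy atoms to 3, without a change that stands out from the scatter. Nothing measured on these compounds accounts for this result.

Compound 1 differs from compound 2 and compound 3 in more than one place, so its much lower number still cannot be assigned to the group on the carbonyl carbon, to the rest of the molecule, or to both together. On these data alone, it also remains open how a carboxylic acid or a longer chain such as butoxy would behave on this carbonyl carbon, and whether the methylamino group of compound 1 would give a different number if it were placed on the core of compound 3.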